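Cytotoxicity notes: carboxymethyl replaces isopropyl on the chain

This account rests on a few compounds, and the source may have more. Where it says the series, first, only, none or still open, it means among the compounds named here.

Three members of the series have been measured in a functional assay on FaDu cells (Homo sapiens) for cytotoxicity, read by MTT assay, with a stated time of 72 h; a lower number here means that less compound is tolerated, a higher number that more compound is tolerated. Compound 1 `CCn1cc(C(=O)C(=O)Nc2ccncc2)c2ccccc21` gives > 10000 nM, which is a limit of the assay and not a number. Compound 2 `COc1nc(NC(=O)C(=O)c2cn(C(C)C)c3ccccc23)ns1` also stops at > 10000 nM, again a limit. Going by the values given here, compound 3 `COc1ccc(NC(=O)C(=O)c2cn(CC(C)C)c3ccccc23)cn1` is the one member with a numeric value, 317 nM in this assay, and so it stands apart from the limit of > 10000 nM in this assay, at which 2 of the 3 values shown sit. Among the compounds with values here, no two measured compounds differ in a single place, so no measured step is available for the chain bound to the aromatic nitrogen or for the amide side.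

Compound 4 `COc1ccc(NC(=O)C(=O)c2cn(CCC(=O)O)c3ccccc23)cn1` is not yet measured. Relative to compound 3 the change is carboxymethyl in place of isopropyl on a saturated chain carbon bound to an aromatic nitrogen. Within the data shown here, with no measured step to lean on, the expectation for compound 4 in this assay is a shift toward a higher value beyond the usual scatter, by a 9.5-fold higher number from compound 3 to compound 4 (0.98 log units; beyond the scatter). The estimate for compound 4 is 3000 nM, with a range from 800 nM to 10000 nM, and a fair chance that the assay returns only a limit.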

Compound 4, concentration lethal to 50% of the cells: > 10000 nM
Compound 4 gave a limit, no number (the forecaster's own chance of this, stated with the estimate: 35%); middle value at least 3.3-fold (0.52 log units) from the limit.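

At the saturated chain carbon bound to an aromatic nitrogen, carboxymethyl in place of isopropyl now has a measured result in this assay: the change gives an at least 31-fold higher number from compound 3 to compound 4 (1.49 log units; beyond the scatter). On these data alone, compound 4 gives > 10000 nM, which is a limit of the assay and not a number, so the true size of the step stays unknown on the high side. Going by these compounds alone, with the amide side held as in compound 3, this chain alone decides between a numeric value and a limit, and compound 3 remains the only member with a number: the limit of > 10000 nM in this assay, at which 3 of the 4 values shown sit.

Open, as far as these compounds go, is whether a methyl ester or a primary amide on the same chain, or a 2-aminoethyl chain, would bring the value back to a number. Compound 1 and compound 2 differ from compound 3 in more than one place, so the ethyl and isopropyl chains cannot be judged separately from their amide sides.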